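Replacing the Ester on the Anilide Ring with Methoxy

The source may report more compounds than this note shows. Statements on the series, on what has been measured and on what is new or still open speak of the compounds shown alone.

Going by the values given here, compound 3, with the structure `CCOC(=O)c1ccc(NC(=O)CSc2nnc(CNc3ccccc3)n2CC)cc1`, is the one compound here with a numerical result in an assay on isolated protein for inhibition of long-chain fatty acid transport protein 1 (Mus musculus) (a higher number here means a weaker inhibitor, a lower number a stronger inhibitor), where compound 3 gives 1100 nM. Compound 1, with the structure `CCn1c(CNc2ccccc2)nnc1SCC(=O)Nc1ccccc1`, reaches only a limit of this assay, and compound 1 gives > 10000 nM. Compound 2, with the structure `CCn1c(CNc2ccccc2)nnc1SCC(=O)Nc1ccc(C(=O)OC)cc1`, has no reported result, and in this assay compound 2 gives "not determined" (no result reported). Among the compounds with values here, the one measured step is an at least 9.0-fold lower number from compound 1 to compound 3 (0.95 log units; beyond the scatter). Compound 4, with the structure `CCn1c(CNc2ccccc2)nnc1SCC(=O)Nc1ccc(OC)cc1`, is not yet measured and differs from compound 3 in one place: methoxy in place of ethoxycarbonyl on an aromatic carbon. The change removes the ethoxycarbonyl whose arrival produced the measured step; a methoxy enters on the same aromatic carbon. The step from compound 1 to compound 3 therefore bears on this change, and since it was large, some loss is expected when the ethoxycarbonyl leaves, with the methoxy of uncertain effect. The expected step is a 4.1-fold higher number from compound 3 to compound 4 (0.61 log units; beyond the scatter), so compound 4 is estimated at 4500 nM, within a range from 1200 nM to 15000 nM.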

Compound 4, half-maximal inhibitory concentration: > 10000 nM
Compound 4 ended at the assay's limit; the forecaster's own chance of this, stated with the estimate: 35%; middle value at least 2.2-fold (0.34 log units) from the limit.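

In this assay, the change gives an at least 9.0-fold higher number from compound 3 to compound 4 (0.95 log units; beyond the scatter), so methoxy on this aromatic carbon does not keep what ethoxycarbonyl gave. Until now, ethoxycarbonyl had been compared only with hydrogen, and this second comparison shows that, of the two groups tried here, only ethoxycarbonyl gives a measurable number, so merely placing a group on this carbon is not enough. The step from compound 1 to compound 4 cannot be read, because each compound ends at the same limit of the assay, which is not a number: the limit of > 10000 nM in this assay, at which 2 of the 4 values shown sit.

The compounds shown leave open which part of the ethoxycarbonyl matters, the carbonyl or the ethyl chain. A carboxylic acid or a longer ester chain on this carbon would help to separate the two.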